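This account rests on a few compounds, and the source may have more. Where it says the series, first, only, none or still open, it means among the compounds named here.

Going by the values given here, in a functional assay on HeLa cells (Homo sapiens) for cytotoxicity, read by MTT assay, with a stated time of 72 h (a higher number here means a weaker inhibitor, a lower number a stronger inhibitor), none of the measured compounds has yet given a number. Compound 1 `CC(C)(C)c1nc2ccccc2n1C(=O)c1cccc2ccccc12` reads > 10000 nM, which is a limit. Compound 2 `O=C(c1cccc2ccccc12)n1c(C2CCC2)nc2ccccc21` reads > 10000 nM, also a limit. Compound 3 `COc1ccc(C(=O)n2c(C(C)C)nc3ccccc32)cc1` reads > 10000 nM, again a limit. The series therefore stands at the limit of > 10000 nM in this assay, at which 3 of the 3 values shown sit. Compound 4 `COc1ccc(C(=O)n2c(-c3ccc(OC)cc3)nc3ccccc32)cc1` carries 4-methoxyphenyl in place of the isopropyl of compound 3 on an aromatic carbon: 4-methoxyphenyl in place of isopropyl on an aromatic carbon. Among the compounds with values here, the only measured step, a step that the two limits leave unreadable from compound 1 to compound 2, exchanges tert-butyl for cyclobutyl, and its size cannot be read, so it gives no firm guide. Only a small change is expected, with no confident direction: an estimated at least 1.1-fold lower number from compound 3 to compound 4 (0.04 log units; that floor lies within the scatter). The estimate for compound 4 is 9000 nM, with an expected range from 2500 nM to 30000 nM.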

Compound 4, half-maximal inhibitory concentration: > 10000 nM
Compound 4: a limit, no number (the forecaster's own chance of this, stated with the estimate: 70%); middle value at least 1.1-fold (0.04 log units) from the limit.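

Compound 3 and compound 4 both read as limits, not numbers, and the step between them, 4-methoxyphenyl in place of isopropyl, cannot be read. The compounds shown leave open which change, if any, would give a measurable number: the limit of > 10000 nM in this assay, at which 4 of the 4 values shown sit.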